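Hexyl-substituted triazole series: chloro in place of fluoro

The compounds below may be only part of what the source reports. "The series", "measured", "known", "first", "only" and "open" are said of these compounds alone.

In a functional assay on HeLa cells (Homo sapiens) for antiproliferative activity, read by MTT assay, with a stated time of 72 h (on this read-out lower numbers stand for stronger inhibition and higher numbers for weaker inhibition), compound 1 `O=c1nc2oc(C3CC3)c(C#CC3CC3)c2cn1Cc1cn(-c2ccccc2F)nn1` gives 51200 nM. Compound 2 `CCCCCCC#Cc1c(CCCCCC)oc2nc(=O)n(Cc3cn(-c4ccc(F)cc4)nn3)cc12` carries a hexyl chain and a heptynyl chain on the shared core and a 4-fluorophenyl group on the triazole. In this assay compound 2 gives only a limit, > 100000 nM, and no number. Going by the values given here, of the two values shown, one sits at this limit, as noted in the limit of > 100000 nM in this assay, at which 1 of the 2 values shown sits; compound 2 therefore stands at the weak end of what the numbers can show, with compound 1 the only compound that gives a number at all.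

Compound 3 `CCCCCCC#Cc1c(CCCCCC)oc2nc(=O)n(Cc3cn(-c4ccc(Cl)cc4)nn3)cc12` is not yet measured. It differs from compound 2 by chloro in place of fluoro on an aromatic carbon. Among the compounds with values here, no step between measured compounds covers this change, so its size is not known from the series. The expectation is that the step from compound 2 to compound 3, a step that the limit leaves unreadable from compound 2 to compound 3, lies within the scatter, with the assay likely to report again only a limit. For compound 3 the estimate in this assay is 120000 nM, with a range from 40000 nM to 400000 nM.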

Compound 3, half-maximal inhibitory concentration: > 100000 nM
Compound 3: only a limit was reported; the forecaster's own chance of this, stated with the estimate: 70%; the middle value lies beyond the limit too.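

Compound 2 and compound 3 both give only a limit and no number in this assay, so no step can be read for chloro in place of fluoro on an aromatic carbon: the limit of > 100000 nM in this assay, at which 2 of the 3 values shown sit.

The compounds shown leave open how 4-fluorophenyl and 4-chlorophenyl compare on the triazole where this read-out returns a number.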